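The source may report more compounds than this note shows. Statements on the series, on what has been measured and on what is new or still open speak of the compounds shown alone.

Compound 1: `COc1ccc(-c2cc(/C=C/C(=O)c3ccc(N)cc3)[nH]n2)cc1` gives 105% in a functional assay on M14 cells (Homo sapiens) for cytotoxicity, read by sulforhodamine B assay, with a stated time of 48 h, tested at 1 uM; a lower number here means a stronger effect, a higher number a weaker effect of the compound at the concentration tested.
Compound 2: `COc1cc(-c2cc(/C=C/C(=O)c3ccc(N)cc3)[nH]n2)cc(OC)c1OC` gives 90% in this assay.
Compound 3: `COc1cc(-c2cc(/C=C/C(=O)c3ccc(Cl)c(Cl)c3)[nH]n2)cc(OC)c1OC` gives 107% in this assay.

Compound 2 stands lowest of the three numbers in this assay. Its nearest neighbour is compound 1, whose number is higher by a margin beyond the scatter; furthest is compound 3, also beyond the scatter. Among the measured compounds shown here, no step is drawn between compound 1 and compound 2, so their two values speak for themselves.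

The unmeasured compound 4 is `COc1cc(-c2cc(/C=C/C(=O)c3ccc(F)c(F)c3)[nH]n2)cc(OC)c1OC`. It differs from compound 2 in one place: 3,4-difluorophenyl in place of 4-aminophenyl on a carbonyl carbon.

For the measured compounds named here, the one measured step that bears on this change is a number 17 percentage points higher from compound 2 to compound 3 (beyond the scatter), where a different dihalogenated phenyl replaced the same 4-aminophenyl on the same carbonyl carbon. That step was modest and upward, beyond the scatter. The change to compound 4 is of the same kind, so a step of about that size and direction is expected in this assay; the step that this expectation means is a number 13 percentage points higher from compound 2 to compound 4 (beyond the scatter).

Compound 4 is therefore estimated at 103% in this assay, within a range from 92% to 115%.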

Compound 4, a percentage reported as activity, at one concentration (the size of the read-out at that concentration, not a potency): 86%
Estimate against measurement, compound 4: 17 percentage points above, outside the stated range (below it).
By their numbers in this assay, from the lowest: compounds 4 and 2 (each within the scatter of the next); then compounds 1 and 3 (each within the scatter of the next).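

In this assay, replacing the 4-aminophenyl on the carbonyl carbon with a dihalogenated phenyl does not by itself give a higher number: the exchange for 3,4-difluorophenyl reads as a number 4 percentage points lower from compound 2 to compound 4 (within the scatter), so the rise seen earlier belongs to the 3,4-dichlorophenyl group alone among the compounds shown. Among the compounds shown here, the two dihalogenated phenyls, which the earlier compounds could not set against each other, also part clearly, with a number 21 percentage points lower from compound 3 to compound 4 (beyond the scatter), so at this place the identity of the halogen counts for more than the removal of the 4-aminophenyl, with its hydrogen-bond donor and acceptor. Nothing available explains why the fluorine and chlorine pair differ in this way.

The compounds shown leave open whether one halogen is enough, as a 4-fluorophenyl or a 4-chlorophenyl on the same carbonyl carbon would show, and whether a 3,4-dibromophenyl would continue the difference between the two halogens. For the compounds shown here, they also leave open whether the 3,4-difluorophenyl behaves the same way on the core of compound 1, with its single methoxy group, and all of this rests on a single tested concentration.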